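The compounds below may be only part of what the source reports. "The series", "measured", "known", "first", "only" and "open" are said of these compounds alone.

Compound 1, `CC(C)COC(=O)NS(=O)(=O)Nc1cccc(-c2cc3ccccc3[nH]2)c1`, in an assay for inhibition of Polyunsaturated fatty acid lipoxygenase ALOX15 (Oryctolagus cuniculus), read by spectrophotometry (a higher number here means a weaker inhibitor, a lower number a stronger inhibitor), gives > 50000 nM, a limit of the assay rather than a number. Compound 2, `COc1ccc(-c2cc3ccccc3[nH]2)cc1NS(=O)(=O)NC(=O)OCC(C)C`, in this assay gives > 50000 nM, again a limit. Compound 3, `C=CCOC(=O)NS(=O)(=O)Nc1cc(-c2cc3cc(F)ccc3[nH]2)ccc1OC`, in this assay gives 23300 nM. The only single-point step among these, a step that the two limits leave unreadable from compound 1 to compound 2, is left unreadable by the two limits, and the limit of > 50000 nM in this assay, at which 2 of the 3 values shown sit, marks where most of the shown values sit. Compound 4 is `CCCCCCCCOC(=O)NS(=O)(=O)Nc1cccc(-c2cc3ccccc3[nH]2)c1`; it differs from compound 1 by heptyl in place of isopropyl on a saturated chain carbon bound to an oxygen next to a carbonyl group. Going by the values given here, no measured step touches the carbamate chain, so no direction can be drawn for this assay beyond the scatter. Given that compound 1 sits at > 50000 nM, compound 4 is expected near 50000 nM, with a range from 15000 nM to 150000 nM, a step of a number no higher from compound 1 to compound 4 (the limit leaves the size open).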

Compound 4, half-maximal inhibitory concentration: 2790 nM
Beside the measured number, compound 4's estimate is 18-fold (1.25 log units) above it; the measured number lies below the stated range.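

In this assay, the carbamate chain now has a readable step: heptyl in place of isopropyl gives an at least 17-fold lower number from compound 1 to compound 4 (1.25 log units; beyond the scatter). Going by these compounds alone, this position, on a saturated chain carbon bound to an oxygen next to a carbonyl group, therefore responds to the change, whereas the earlier compounds offered no step here. Part of the series still stands at a limit: the limit of > 50000 nM in this assay, at which 2 of the 4 values shown sit.

This single pair cannot separate chain length from the loss of branching. On these data alone, how a longer chain than octyl, or a chain ending in an amine or a carboxylic acid, would read remains open.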